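The compounds below may be only part of what the source reports. "The series", "measured", "known", "first", "only" and "open" are said of these compounds alone.

Measured so far:
Compound 1 `COc1cccc(/C=C/C(=O)c2sc(Nc3ccccc3)nc2C)c1` — in a functional assay on PC-3 cells (Homo sapiens) for cytotoxicity, read by MTT assay (a lower number here means a stronger inhibitor, a higher number a weaker inhibitor), compound 1 gives > 25000 nM, a limit of the assay.
Compound 2 `Cc1nc(Nc2ccccc2)sc1C(=O)/C=C/c1ccc(Cl)cc1` — in this assay compound 2 gives > 25000 nM, also a limit of the assay.

Compound 2 therefore stands at the limit, and the change from compound 1, a step that the two limits leave unreadable from compound 1 to compound 2, cannot be read because of the limit of > 25000 nM in this assay, at which 2 of the 2 values shown sit. Compound 3 `Cc1ccccc1Nc1nc(C)c(C(=O)/C=C/c2ccc(Cl)cc2)s1` differs from compound 2 by methyl in place of hydrogen on an aromatic carbon. For the measured compounds named here, no measured step bears on this change, and the starting point is itself only a limit. The step that the limit leaves unreadable from compound 2 to compound 3 is therefore expected, which would most likely leave compound 3 beyond the limit as well. The estimate for compound 3 in this assay is 40000 nM, between 10000 nM and 160000 nM.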

Compound 3, half-maximal inhibitory concentration: > 25000 nM
Compound 3 gave a limit, no number; the forecaster's own chance of this, stated with the estimate: 75%; the middle value does not contradict the limit.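

In this assay no step can be read from compound 2 to compound 3, since both stand at a limit: the limit of > 25000 nM in this assay, at which 3 of the 3 values shown sit. The compounds shown leave open whether any change to the shared core gives a readable value, and what the added methyl does to potency.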